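Carbamoyloxymethyl at the benzylic carbon of compound 1

The source may hold more compounds than are shown below. What is called first, only, known or untested is meant among the compounds shown, and "the series" means these compounds.

Measured so far:
- compound 1, `c1ccc(CNC2CCN(CCCc3c[nH]c4ccc(-n5cnnc5)cc34)CC2)cc1`: 7.6 nM
- compound 2, `COC[C@H](NC1CCN(CCCc2c[nH]c3ccc(Cn4cncn4)cc23)CC1)c1ccc(F)cc1`: 8.9 nM

Both numbers come from an assay on CHO cells for agonist activity at 5-hydroxytryptamine receptor 1D (Homo sapiens), read by GTPgammaS binding; on this read-out higher numbers stand for an effect only at larger amounts of compound and lower numbers for an effect already at smaller amounts. Compound 1 holds the lowest of the two numbers; the nearest is compound 2, whose number lies within the scatter of that of compound 1, so no order between compound 1 and compound 2 can be read from this assay. Compound 2 is a different structure in more than one place, and its value is taken only as a second point in the same range.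

Compound 3, `NC(=O)OC[C@H](NC1CCN(CCCc2c[nH]c3ccc(-n4cnnc4)cc23)CC1)c1ccccc1`, has not been measured in this assay. Relative to compound 1 it differs in one place: (carbamoyloxy)methyl in place of hydrogen on a saturated chain carbon bound to an amine nitrogen and an aromatic carbon. Among the compounds with values here, no step between two measured compounds covers this difference, so the expectation rests on the two values alone and on the fact that compound 2, which carries a substituent on the corresponding carbon, gives a number within the scatter of compound 1.

The step from compound 1 to compound 3 in this assay is expected to be a 1.1-fold higher number from compound 1 to compound 3 (0.02 log units; within the scatter), that is, none beyond the scatter. Compound 3 is estimated at 8 nM, with a range from 3 nM to 25 nM.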

Compound 3, half-maximal effective concentration: 9.3 nM
Compound 3: the middle estimate sits 1.2-fold (0.07 log units) below what was measured; the measured number falls inside the stated range.
By their numbers in this assay, from the lowest: compounds 1, 2 and 3 (each within the scatter of the next).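

Within the data shown here, the only one-place comparison at this position in this assay is a 1.2-fold higher number from compound 1 to compound 3 (0.09 log units; within the scatter). On the core of compound 1, a saturated chain carbon bound to an amine nitrogen and an aromatic carbon can therefore carry (carbamoyloxy)methyl, with 5 heavy atoms, no ring and no net charge, in place of hydrogen, and compound 1 and compound 3 still cannot be ordered; compound 2, which differs from compound 1 in more than one place, could not show this for a single substitution. No measurement bears on why the two numbers stay within the scatter of each other.

This single step does not show whether the same holds for other groups at this carbon, such as hydroxymethyl, aminomethyl, a carboxylic acid or a longer chain, or for a simple methyl that would separate the added carbon from the carbamate. Going by these compounds, the opposite configuration at this carbon is also open, as is whether (carbamoyloxy)methyl behaves the same way on a core other than that of compound 1.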